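Methyl on the Indole Nitrogen of a Weak Cinnamide

The source may report more compounds than this note shows. Statements on the series, on what has been measured and on what is new or still open speak of the compounds shown alone.

In an assay on C6 cells for antagonist activity at prostaglandin E2 receptor EP2 subtype (Homo sapiens), read by TR-FRET, with stated times of 10 min and 40 min, tested at 1 uM (a lower number here means a stronger inhibitor, a higher number a weaker inhibitor), compound 1 `COc1ccc(/C=C/C(=O)NCCn2c(C(F)(F)F)cc3ccccc32)cc1` gives 305 nM. Compound 2 `COc1cc(/C=C/C(=O)NCc2c(C)[nH]c3ccccc23)cc(OC)c1OC` is reported in this assay only as a limit, > 1000 nM, and so it sits at the weak end of what is shown here (the limit of > 1000 nM in this assay, at which 1 of the 2 values shown sits). Compound 3 `COc1cc(/C=C/C(=O)NCc2c(C)n(C)c3ccccc23)cc(OC)c1OC` has not yet been measured; it differs from compound 2 by methyl in place of hydrogen on an aromatic nitrogen. Going by the values given here, with no measured step of this kind to rest on, the change is expected to move this assay by no more than the scatter, as a step that the limit leaves unreadable from compound 2 to compound 3. Compound 3 is therefore estimated at 1500 nM, between 500 nM and 5000 nM.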

Compound 3, antagonist equilibrium constant: > 1000 nM
Compound 3 gave a limit, no number; the forecaster's own chance of this, stated with the estimate: 60%; the middle value is on the limit's open side.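

Going by these compounds alone, compound 2 and compound 3 are both reported only as limits in this assay, and no step between them can be read. Going by these compounds, how far methyl in place of hydrogen on an aromatic nitrogen moves the value remains open.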